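The source may hold more compounds than are shown below. What is called first, only, known or untested is meant among the compounds shown, and "the series" means these compounds.

In an ADME assay on HEK293 cells (Homo sapiens) for cytotoxicity, read by resazurin assay, with a stated time of 48 h (on this read-out lower numbers stand for higher toxicity in this test and higher numbers for lower toxicity in this test), compound 1 `O=S(=O)(Nc1ccc(-c2nc3ccccc3o2)cc1)c1ccc(Cl)c(C(F)(F)F)c1` gives 69000 nM and compound 2 `Cc1ccc(S(=O)(=O)Nc2ccc(-c3nc4ccccc4o3)cc2)cc1` gives 88000 nM. Compound 3 `O=S(=O)(Nc1ccc(-c2nc3ccccc3o2)cc1)c1ccc(Cl)s1` reads > 100000 nM, which is a limit and not a number. It stands at the limit of > 100000 nM in this assay, at which 1 of the 3 values shown sits. Compound 4 `O=S(=O)(Nc1ccc(-c2nc3ccccc3o2)cc1)c1cccc(Cl)c1` differs from it as follows: 3-chlorophenyl in place of 5-chlorothiophen-2-yl on a sulfonyl sulfur. For the measured compounds named here, the one measured step at this place is an at least 1.1-fold higher number from compound 2 to compound 3 (0.05 log units; that floor lies within the scatter), with 5-chlorothiophen-2-yl in place of 4-methylphenyl on a sulfonyl sulfur, and it lies within the scatter. No change beyond the scatter is therefore expected in this assay. The expected size is an at least 1.1-fold lower number from compound 3 to compound 4 (0.07 log units; that floor lies within the scatter), toward lower numbers if any. For compound 4 the estimate is 85000 nM, with an expected range of 45000 nM to 125000 nM.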

Compound 4, half-maximal cytotoxic concentration: > 100000 nM
Compound 4 ended at the assay's limit; the forecaster's own chance of this, stated with the estimate: 35%; middle value at least 1.1-fold (0.07 log units) from the limit.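

In this assay, compound 4 shows that 3-chlorophenyl, a six-membered aromatic ring of carbon only, on the sulfonyl sulfur also ends at the assay's limit, as 5-chlorothiophen-2-yl did in compound 3. Against 4-methylphenyl the reading is an at least 1.1-fold higher number from compound 2 to compound 4 (0.05 log units; that floor lies within the scatter). The step from compound 3 to compound 4 cannot be read, because both values are limits: the limit of > 100000 nM in this assay, at which 2 of the 4 values shown sit.

Still open, on these data alone, is what numbers lie behind these two limits. Also open, as far as these compounds go, is whether an amine or a carboxylic acid on this ring would give a lower number in this assay.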